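Adding a hydroxy group to compound 2: an expected read-out

The source may report more compounds than this note shows. Statements on the series, on what has been measured and on what is new or still open speak of the compounds shown alone.

Measured compounds:
Compound 1 `CC(C)(C)C1=NN(c2ccc(C(=O)O)cc2)C(c2ccc(O)cc2)C1` gives 47.9% in an assay on isolated protein for inhibition of protein kinase C zeta type (Homo sapiens), with a stated time of 4 min, tested at 62.5 uM; a lower number here means less inhibition, a higher number more inhibition at the concentration tested (going by the name of the read-out).
Compound 2 `Oc1ccc(C2CC(c3ccccc3)=NN2c2ccc(Cl)cc2)cc1` gives 95.6% in this assay.
Compound 3 `Oc1ccc(C2CC(c3ccccc3)=NN2c2cccc(Cl)c2)cc1` gives 90.5% in this assay.

Compound 2 stands highest of the three numbers. Its nearest neighbour is compound 3, and the step of a number 5.1 percentage points lower from compound 2 to compound 3 (within the scatter) lies within the scatter, so the two cannot be ordered. Compound 1 lies far below both, beyond the scatter.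

The unmeasured compound 4 `Oc1ccc(C2CC(c3ccccc3O)=NN2c2ccc(Cl)cc2)cc1` differs from compound 2 in one place: hydroxy in place of hydrogen on an aromatic carbon. Cut one bond further out, this reads phenyl to 2-hydroxyphenyl.

Going by the values given here, none of the measured steps touches this change; the single step on record, from compound 2 to compound 3, concerns the chlorophenyl on the ring nitrogen, not the phenyl carrying the new hydroxy group. There is therefore no measured guide to the size of the step expected in this assay. Since compound 2 already sits close to the top of the scale, the step of a number 5.6 percentage points lower from compound 2 to compound 4 (within the scatter) is expected to be small or none beyond the scatter. Compound 4 is estimated at 90%, within 70% to 100%.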

Compound 4, a percentage reported as inhibition, at one concentration (the size of the read-out at that concentration, not a potency): 92%
Compound 4: the middle estimate sits 2 percentage points below what was measured; the range from low to high includes it.
By their numbers in this assay, from the lowest: compound 1; then compounds 3, 4 and 2 (each within the scatter of the next).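

Going by these compounds alone, until now, the only step on record changed the chlorophenyl on the ring nitrogen, so the phenyl at the other end of the molecule had not been probed. Here, phenyl to 2-hydroxyphenyl gives a number 3.6 percentage points lower from compound 2 to compound 4 (within the scatter) in this assay, so this position accepts a hydroxy group ortho to a large group without a change that can be told from the scatter. No available evidence bears on why the read-out holds at this position.

On these data alone, these are readings at one concentration near the top of the scale, not potencies, so any difference in potency between the two compounds remains open. Also open, as far as these compounds go, is how this assay responds at this same place to a group other than hydroxy, such as an amine or a carboxylic acid.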